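Swapping chloro for fluoro in a bithiophene amidine growth inhibitor

This account rests on a few compounds, and the source may have more. Where it says the series, first, only, none or still open, it means among the compounds named here.

Measured so far:
- compound 1, `COc1ccc(-c2ccc(-c3ccc(C(=N)N)o3)o2)cc1`, 1740 nM
- compound 2, `N=C(N)c1ccc(-c2ccc(-c3ccc(Cl)cc3)s2)s1`, 1830 nM
- compound 3, `COc1cc(OC)cc(-c2ccc(-c3ccc(C(=N)N)o3)o2)c1`, 2450 nM

All three values come from a functional assay on U-251 cells (Homo sapiens) for inhibition, read by sulforhodamine B assay, with a stated time of 48 h; a lower number here means a stronger inhibitor of growth, a higher number a weaker inhibitor of growth. The three numbers sit close together. Compound 2 gives the second highest of the three, but its gap to compound 1 and its gap to compound 3 are both within the scatter of repeated measurements, so no ordering among compounds 1, 2 and 3 can be claimed from these data.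

The next compound, compound 4, `N=C(N)c1ccc(-c2ccc(-c3ccc(F)cc3)s2)s1`, has not been measured yet. It differs from compound 2 in one place: fluoro in place of chloro on an aromatic carbon. Both groups leaving and entering are single heavy atoms without donors or acceptors and without charge, so the change is small in every counted respect.

Among the measured compounds shown here, no pair of measured compounds differing in one place is available here, so there is no measured step to lean on. The expectation rests on the size of the change and on the narrow spread of the three values already seen. A step no larger than the scatter is expected, with no confident direction, from compound 2 to compound 4 in this assay, namely a 1.3-fold higher number from compound 2 to compound 4 (0.10 log units; within the scatter). Compound 4 is therefore estimated at 2300 nM, with a plausible range from 1100 nM to 5000 nM.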

Compound 4, concentration for 50% growth inhibition: 1800 nM
The estimate for compound 4 lay 1.3-fold (0.11 log units) above the measured number; the range from low to high includes it.
By their numbers in this assay, from the lowest: compounds 1, 4, 2 and 3 (each within the scatter of the next).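

Among the compounds shown here, this is the only measured step between two compounds that differ in one place, and it isolates a single position: in this assay, fluoro in place of chloro on an aromatic carbon, para to a large group, gives a 1.0-fold lower number from compound 2 to compound 4 (0.01 log units; within the scatter). The earlier values could not show this, since those compounds differ from one another in more than one place, whereas here one halogen can replace the other at this position without a readable difference in growth inhibition. Nothing measured here speaks to the reason for this match.

The compounds shown cover only these two halogens at this position, so it remains open whether an entirely different group there, such as an amine, a carboxylic acid or a longer alkyl chain, would leave the number just as unchanged or shift it beyond the scatter. As far as these compounds go, it also remains open whether the same swap of chloro for fluoro would read the same on the core of compound 1.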